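A few compounds are considered here, and "the series" means these few. Any claim that something is new, unique, unknown or untested is made for them only; others in the source may bear on it.

Measured so far:
compound 1, `CN(C)CC(=O)N1CCC(NS(=O)(=O)c2cc(S(=O)(=O)c3ccccc3)ccc2C(F)(F)F)CC1`, 280 nM
compound 2, `CCNC(=O)N1CCC[C@H]1C(=O)N1CCC(NS(=O)(=O)c2cc(S(=O)(=O)c3ccccc3)ccc2C(F)(F)F)CC1`, 90 nM

In a functional assay on U2OS cells for antagonist activity at proto-oncogene Wnt-3 (Homo sapiens), read by a luciferase reporter, with a stated time of 18 h (a higher number here means that more compound is needed for the effect, a lower number that less compound is needed), compound 1 stands highest of the two numbers; the nearest is compound 2, reached by a 3.1-fold lower number from compound 1 to compound 2 (0.49 log units; beyond the scatter). Compound 3, `O=C([C@@H]1CCCN1Cc1ccccc1)N1CCC(NS(=O)(=O)c2cc(S(=O)(=O)c3ccccc3)ccc2C(F)(F)F)CC1`, awaits measurement. Relative to compound 1 the change is 1-benzylpyrrolidin-2-yl in place of (dimethylamino)methyl on a carbonyl carbon. The step to compound 2 is the only one that bears on it, since there too a pyrrolidin-2-yl group carrying a substituent on its ring nitrogen took the place of (dimethylamino)methyl, and that step was modest. A step of similar size and direction is therefore expected for compound 3, namely a 2.8-fold lower number from compound 1 to compound 3 (0.45 log units; beyond the scatter). Compound 3 is estimated at 100 nM, range 40 nM to 280 nM.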

Compound 3, half-maximal effective concentration: 720 nM
Estimate against measurement, compound 3: 7.2-fold (0.86 log units) below; the measured number lies above the stated range.
By their numbers in this assay, from the lowest: compound 2; then compound 1; then compound 3.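

In this assay, a pyrrolidin-2-yl group on this carbonyl carbon does not lower the number by itself: 1-benzylpyrrolidin-2-yl in place of (dimethylamino)methyl gives a 2.6-fold higher number from compound 1 to compound 3 (0.41 log units; beyond the scatter) and so runs opposite to the earlier step. On the amine nitrogen in the ring, benzyl in place of ethylcarbamoyl gives an 8.0-fold higher number from compound 2 to compound 3 (0.90 log units; beyond the scatter), so the outcome at this position depends on the group carried by that nitrogen. No measurement at hand offers an explanation for this.

Open, as far as these compounds go, is how a pyrrolidin-2-yl group with a free ring amine, or one carrying an acetyl group on that nitrogen, would compare. Also open, from the compounds shown here alone, is whether a methylcarbamoyl or a longer alkylcarbamoyl chain would hold the number of compound 2.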